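The source may report more compounds than this note shows. Statements on the series, on what has been measured and on what is new or still open speak of the compounds shown alone.

Measured compounds in a functional assay on CEM-DNR-bulk cells (Homo sapiens), read by MTT assay, with a stated time of 72 h; on this read-out lower numbers stand for stronger inhibition and higher numbers for weaker inhibition:
compound 1 `COc1ncnc2c1c(-c1ccoc1)cn2[C@@H]1O[C@H](CO)[C@@H](O)[C@H]1O` — > 20000 nM, a limit of the assay
compound 2 `Cc1ncnc2c1c(-c1ccoc1)cn2[C@@H]1O[C@H](CO)[C@@H](O)[C@H]1O` — > 20000 nM, a limit of the assay

Compound 1 stands at the limit of this assay, with only a limit and no number; its reading of > 20000 nM says no more than that. Compound 2 stands at the same limit. Among the compounds with values here, the one step measured, a step that the two limits leave unreadable from compound 1 to compound 2, cannot be read in size or direction because the limit of > 20000 nM in this assay, at which 2 of the 2 values shown sit, holds both values.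

Compound 3 `COc1nc(N)nc2c1c(-c1ccoc1)cn2[C@@H]1O[C@H](CO)[C@@H](O)[C@H]1O` differs from compound 1 by amino in place of hydrogen on an aromatic carbon. Within the data shown here, no measured step concerns this position, and the only step measured, a step that the two limits leave unreadable from compound 1 to compound 2, gives no size to lean on. With compound 1 at the limit, there is no basis for expecting a change in either direction beyond the scatter, and the most plausible outcome is a further limit. Compound 3 is therefore estimated at 30000 nM, within 8000 nM to 100000 nM, and the step that the limit leaves unreadable from compound 1 to compound 3 is expected to be unreadable against the limit.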

Compound 3, half-maximal inhibitory concentration: > 20000 nM
Compound 3: no number, only a limit (the forecaster's own chance of this, stated with the estimate: 80%); the middle value lies beyond the limit too.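

Compound 3 gives > 20000 nM, a limit of the assay and not a number. No step from compound 1 to compound 3 can be read, because the values share one limit: the limit of > 20000 nM in this assay, at which 3 of the 3 values shown sit.

The compounds shown leave open whether any change on the shared core gives a measurable value.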